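A few compounds are considered here, and "the series" means these few. Any claim that something is new, unique, unknown or untested is made for them only; others in the source may bear on it.

Measured so far in an assay on DDT1 cells (Cricetulus griseus) for binding affinity to adenosine receptor A1 (Homo sapiens), read by radioligand binding; on this read-out lower numbers stand for stronger inhibition and higher numbers for weaker inhibition:
- compound 1, `CCNC(=O)OC[C@H]1OC(n2cnc3c(NC4CCOC4)ncnc32)[C@H](O)[C@@H]1O`, gives 167 nM
- compound 2, `CC/N=C(\S)OC[C@H]1OC(n2cnc3c(NC4CCOC4)ncnc32)[C@H](O)[C@@H]1O`, gives 33 nM
- compound 3, `CC/N=C(\S)OC[C@H]1OC(n2cnc3c(NC4CCOC4)nc(Cl)nc32)[C@H](O)[C@@H]1O`, gives 55 nM

Compound 2 gives the lowest of the three numbers in this assay. Its nearest neighbour is compound 3, reached by a 1.7-fold higher number from compound 2 to compound 3 (0.22 log units; within the scatter), a gap that stays within the scatter, so the two cannot be ranked against each other. The furthest is compound 1: the step of a 5.1-fold lower number from compound 1 to compound 2 (0.70 log units; beyond the scatter) is the only one beyond the scatter among the measured pairs.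

Compound 4, `CCC/N=C(\S)OC[C@H]1OC(n2cnc3c(NC4CCOC4)ncnc32)[C@H](O)[C@@H]1O`, has not yet been measured. It differs from compound 2 by methyl in place of hydrogen on a saturated chain carbon, two bonds along the chain from a double-bonded nitrogen. Neither measured step bears directly on this change: the step from compound 1 to compound 2 exchanges an oxygen-containing group for a sulfur-containing group, and the step from compound 2 to compound 3 adds a chloro on an aromatic carbon, whereas compound 4 only lengthens the chain on the double-bonded nitrogen, ethyl to propyl. For the measured compounds named here, with no comparable step on record, a change within the scatter is expected, in no firm direction. The estimate for compound 4 is therefore 35 nM, with a range from 12 nM to 100 nM, which means an expected step of a 1.1-fold higher number from compound 2 to compound 4 (0.03 log units; within the scatter).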

Compound 4, inhibition constant: 50 nM
For compound 4 the middle estimate is 1.4-fold (0.15 log units) below the measured one; the range from low to high includes it.
By their numbers in this assay, from the lowest: compounds 2, 4 and 3 (each within the scatter of the next); then compound 1.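

In this assay the chain on the double-bonded nitrogen goes from ethyl to propyl in compound 4, giving a 1.5-fold higher number from compound 2 to compound 4 (0.18 log units; within the scatter) and leaving compound 2 and compound 4 unranked against each other. The earlier compounds shown here held no change at this position; this single step shows that methyl in place of hydrogen on a saturated chain carbon, two bonds along the chain from a double-bonded nitrogen, does not carry the number beyond the scatter here. The separation from the oxygen-containing group also holds with the propyl chain, as a 3.3-fold lower number from compound 1 to compound 4 (0.52 log units; beyond the scatter) shows, although no measurement at hand gives a reason for either step.

One step along one chain says little about a longer chain such as butyl, a branched group such as isopropyl, or a ring such as cyclopentyl on the same nitrogen, any of which might read differently in this assay and show how far this position stays within the scatter. Going by these compounds, it also remains open whether the propyl chain and the chloro on the aromatic carbon of compound 3 would read the same when combined in one compound.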